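Aryl replacement on the five-membered ring nitrogen

The source may report more compounds than this note shows. Statements on the series, on what has been measured and on what is new or still open speak of the compounds shown alone.

Compound 3 `CN(CCNCc1cn(C(C)(C)C)nn1)CCNc1ccnc2cc(Cl)ccc12` gives 79000 nM in a functional assay on NCI-H460 cells (Homo sapiens) for antiproliferative activity, read by sulforhodamine B assay, with a stated time of 72 h (on this read-out higher numbers stand for weaker inhibition and lower numbers for stronger inhibition), the highest number of the three measured. Compound 1 `CN(CCNCc1cn(-c2ccccc2)nn1)CCNc1ccnc2cc(Cl)ccc12` gives 25000 nM, and compound 2 `CN(CCNCc1cn(-c2ccccc2Cl)nn1)CCNc1ccnc2cc(Cl)ccc12` gives 20000 nM; these two lie within the scatter of each other, as a 1.3-fold lower number from compound 1 to compound 2 (0.10 log units; within the scatter) shows. The two steps that reach compound 3 both exchange an aromatic group for tert-butyl on the aromatic nitrogen: a 3.2-fold higher number from compound 1 to compound 3 (0.50 log units; beyond the scatter) and a 4.0-fold higher number from compound 2 to compound 3 (0.60 log units; beyond the scatter), each a modest rise beyond the scatter.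

Compound 4 `CN(CCNCc1cn(Cc2nc3cc(Cl)ccc3[nH]2)nn1)CCNc1ccnc2cc(Cl)ccc12` follows the change ((5-chloro-1H-benzimidazol-2-yl)methyl in place of tert-butyl on an aromatic nitrogen). Here a group holding two aromatic rings, one five-membered with 2 hetero atoms and one six-membered of carbon only, enters where tert-butyl left, so the step is read as a partial return toward compound 1 and compound 2, though the new group carries 1 hydrogen-bond donor and 1 hydrogen-bond acceptor and sits through a methylene rather than directly. A modest fall is therefore expected, about a 3.2-fold lower number from compound 3 to compound 4 (0.50 log units; beyond the scatter). In this assay compound 4 is expected near 25000 nM, within 8000 nM to 70000 nM.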

Compound 4, half-maximal inhibitory concentration: 59000 nM
The estimate for compound 4 lay 2.4-fold (0.37 log units) below the measured number, and the stated range covers the measured number.
By their numbers in this assay, from the lowest: compounds 2 and 1 (each within the scatter of the next); then compounds 4 and 3 (each within the scatter of the next).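

In this assay, (5-chloro-1H-benzimidazol-2-yl)methyl in place of tert-butyl gives a 1.3-fold lower number from compound 3 to compound 4 (0.13 log units; within the scatter), so at this position a much larger group with aromatic rings does not separate from tert-butyl. The same group does separate from both aryl groups, with a 2.4-fold higher number from compound 1 to compound 4 (0.37 log units; beyond the scatter) and a 3.0-fold higher number from compound 2 to compound 4 (0.47 log units; beyond the scatter), so aromatic rings in the new group are not enough to reach the level of phenyl or 2-chlorophenyl in this set of compounds. No evidence available here bears on the reason for this result.

As far as these compounds go, whether the gap from the aryl groups follows from the methylene or from the two rings remains open; a benzyl group on the same nitrogen would help separate these two parts. Also open, from the compounds shown here alone, is how an amine or a carboxylic acid on the phenyl ring would change the number.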